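Para substituent on the anilino ring: fluoro to trifluoromethoxy

The source may report more compounds than this note shows. Statements on the series, on what has been measured and on what is new or still open speak of the compounds shown alone.

Compound 1 `O=C(C1=C(O)C(=O)N(CCCn2ccnc2)C1c1ccc(Br)cc1)c1ccccc1` is reported as "not active" (no number reported) in a functional assay on U2OS cells (Homo sapiens) for antiproliferative activity, read by MTT assay, with a stated time of 72 h (on this read-out higher numbers stand for weaker inhibition and lower numbers for stronger inhibition), with no number given. Compound 2 `CCOc1ccc(NC2=C(C(=O)c3ccccc3)C(c3ccc(Br)cc3)N(CCCn3ccnc3)C2=O)cc1` gives 26200 nM in this assay, and compound 3 `O=C(C1=C(Nc2ccc(F)cc2)C(=O)N(CCCn2ccnc2)C1c1ccc(Br)cc1)c1ccccc1` gives 30000 nM, the higher of the two numbers, although the step of a 1.1-fold higher number from compound 2 to compound 3 (0.06 log units; within the scatter) lies within the scatter. Compound 4 `O=C(C1=C(Nc2ccc(OC(F)(F)F)cc2)C(=O)N(CCCn2ccnc2)C1c1ccc(Br)cc1)c1ccccc1` differs from compound 3 by trifluoromethoxy in place of fluoro on an aromatic carbon. Among the compounds with values here, the only measured step that touches the same group is a 1.1-fold higher number from compound 2 to compound 3 (0.06 log units; within the scatter), and it stayed within the scatter; no other comparison bears on it. No step beyond the scatter is therefore expected in this assay. For compound 4 the expected step is no change at the digits printed from compound 3 to compound 4 (within the scatter), which gives an estimate of 30000 nM within 10000 nM to 90000 nM.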

Compound 4, half-maximal inhibitory concentration: 11500 nM
For compound 4 the middle estimate is 2.6-fold (0.42 log units) above the measured one; the range from low to high includes it.
By their numbers in this assay, from the lowest: compound 4; then compounds 2 and 3 (each within the scatter of the next).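

In this assay this position, para to a large group, now shows steps beyond the scatter, which compound 2 and compound 3 had not shown: trifluoromethoxy in place of fluoro gives a 2.6-fold lower number from compound 3 to compound 4 (0.42 log units; beyond the scatter), and trifluoromethyl in place of ethyl on the oxygen gives a 2.3-fold lower number from compound 2 to compound 4 (0.36 log units; beyond the scatter). Both steps are modest, so the position responds to substitution only to a limited degree so far. No measurement here bears on the reason for the steps.

Going by these compounds, whether the oxygen or the fluorines carry the step remains open. A methoxy group, a trifluoromethyl group or a dimethylamino group on this carbon would help separate the two.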